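Removing the Carbamoyloxy Group from Compound 2

A few compounds are considered here, and "the series" means these few. Any claim that something is new, unique, unknown or untested is made for them only; others in the source may bear on it.

Of the compounds shown here, two sharing one core have been measured in a functional assay on L1210 cells (Mus musculus), with a stated time of 12 days; a lower number here means a less potent compound, a higher number a more potent compound, by a factor of ten per unit of this negative logarithm. Compound 1 `CCC1=C(N2CC2)C(=O)C(C(COC(N)=O)OC)=C(N2CC2)C1=O` gives 6.16. Among the measured compounds shown here, compound 2 `CCC1=C(N2CC2)C(=O)C(CCOC(N)=O)=C(N2CC2)C1=O` gives 6.25, and of the two numbers measured so far it lies nearest to compound 1, the two being within the scatter of each other. For the measured compounds named here, the only measured step, a number 0.09 log units higher from compound 1 to compound 2 (within the scatter), is hydrogen in place of methoxy on a saturated chain carbon bound to a double-bonded ring carbon and a saturated chain carbon, and it shows nothing beyond noise.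

Compound 3 `CCC1=C(N2CC2)C(=O)C(CC)=C(N2CC2)C1=O` is not yet measured. It differs from compound 2 as follows: hydrogen in place of carbamoyloxy on a saturated chain carbon, two bonds along the chain from a double-bonded ring carbon. Going by the values given here, no measured step removes a carbamoyloxy group, so the single step within the scatter gives no direct guide, and the expectation rests on the shared core alone. Compound 3 is therefore expected to give about 5.7, within a wide range from 5 to 6.4. This estimate means an expected step of a number 0.55 log units lower from compound 2 to compound 3 (beyond the scatter), downward but uncertain in size.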

Compound 3, logarithm of the reciprocal of the active concentration, log(1/C): 5.46
Compound 3: middle estimate off by 0.24 log units, on the high side; the measured number falls inside the stated range.
By their numbers in this assay, from the lowest: compound 3; then compounds 1 and 2 (each within the scatter of the next).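

In this assay, removing the carbamoyloxy group gives a number 0.79 log units lower from compound 2 to compound 3 (beyond the scatter) and so, unlike the earlier methoxy change, moves the number by more than noise. Replacing the whole side chain with ethyl on the double-bonded ring carbon gives a number 0.70 log units lower from compound 1 to compound 3 (beyond the scatter) and points the same way: among these three compounds, the two that carry carbamoyloxy sit higher than the one that ends in a plain ethyl. Nothing available explains this drop.

From the compounds shown here alone, it remains open whether the carbamoyloxy group itself matters or whether other groups at the same chain end would serve equally well, which a hydroxyl, an amine or a carboxylic acid there could help separate. A longer chain ending in carbamoyloxy would also show how far this group can sit from the ring carbon.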